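A few compounds are considered here, and "the series" means these few. Any claim that something is new, unique, unknown or untested is made for them only; others in the source may bear on it.

Compound 1 `Cc1ccc(S(=O)(=O)c2cnc3cc(F)ccc3c2N2CCC(C)CC2)cc1C`: 90%
Compound 2 `CC1CCN(c2c(S(=O)(=O)c3cc(Cl)cc(Cl)c3)cnc3ccc(Cl)cc23)CC1`: 88%

Of the compounds shown here, two have been measured in an assay on isolated protein for displacement of a labelled ligand from metabotropic glutamate receptor 5 (Homo sapiens), with a stated time of 60 min, tested at 1 uM; on this read-out higher numbers stand for more inhibition at the one concentration tested (going by the name of the read-out) and lower numbers for less inhibition. Compound 1 gives 90% in this assay, and compound 2 gives 88%. On the numbers shown, compound 1 stands at the top of the two, yet its gap to compound 2 lies within the scatter of this assay, so the two are not separable on this read-out. Both share the same core and carry a substituted phenyl on the sulfonyl sulfur.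

Compound 3 `Cc1cc(C)cc(S(=O)(=O)c2cnc3cc(F)ccc3c2N2CCC(C)CC2)c1` is not yet measured. It differs from compound 1 in one place: 3,5-dimethylphenyl in place of 3,4-dimethylphenyl on a sulfonyl sulfur. The two compounds have the same atoms, joined differently. Going by the values given here, no step between measured compounds informs this change, so its size is open. An expected step of a number 5 percentage points lower from compound 1 to compound 3 (within the scatter) is small, in either direction, and not beyond the scatter. Compound 3 is estimated to give 85% in this assay, with a range from 65% to 96%.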

Compound 3, a percentage reported as inhibition, at one concentration (the size of the read-out at that concentration, not a potency): 80%
Estimate against measurement, compound 3: 5 percentage points above, and the stated range covers the measured number.
By their numbers in this assay, from the lowest: compounds 3, 2 and 1 (each within the scatter of the next).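

In this assay the exchange of 3,4-dimethylphenyl for 3,5-dimethylphenyl on the sulfonyl sulfur gives a number 10 percentage points lower from compound 1 to compound 3 (within the scatter), so this rearrangement of the same atoms does not separate the two compounds on this read-out. Going by these compounds alone, it is the first step read at this position, and it shows that both dimethylphenyl arrangements on the sulfonyl sulfur keep substantial inhibition at the one concentration tested. No measurement shown here bears on the size of this step.

The compounds shown leave open whether a different group on the sulfonyl sulfur, such as an unsubstituted phenyl, a pyridine ring or a carboxylic acid, would give a step beyond the scatter. On these data alone, whether compound 1 and compound 3 would differ in potency across a range of concentrations also remains open.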